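Adding a second bromine to the phenol ring of compound 2

The compounds below may be only part of what the source reports. "The series", "measured", "known", "first", "only" and "open" are said of these compounds alone.

Of the compounds shown here, two have been tested so far in an ADME assay on NIH3T3 cells (Mus musculus) for cytotoxicity, read by MTT assay, with a stated time of 24 h; on this read-out higher numbers stand for weaker inhibition and lower numbers for stronger inhibition. Compound 1 `O=C(CSc1nnc(-c2ccncc2)o1)N/N=C/c1ccc(F)cc1` gives 170000 nM. Within the data shown here, compound 2 `O=C(CSc1nnc(-c2ccncc2)o1)N/N=C/c1cc(Br)ccc1O` gives 156000 nM, and among the two numbers that is the lower one, though its only neighbour is compound 1, and the step of a 1.1-fold lower number from compound 1 to compound 2 (0.04 log units; within the scatter) tells that these two cannot be told apart. Compound 3 `O=C(CSc1nnc(-c2ccncc2)o1)N/N=C/c1cc(Br)cc(Br)c1O` has not been measured yet. It differs from compound 2 in one place: bromo in place of hydrogen on an aromatic carbon. Among the measured compounds shown here, no measured step makes exactly this change. For the measured compounds named here, the only step available, a 1.1-fold lower number from compound 1 to compound 2 (0.04 log units; within the scatter), exchanged the whole phenyl ring bearing the fluoro group for the bromo-hydroxy phenyl ring, and the number stayed where it was. With so small a change and so flat a record, the step of a 1.0-fold lower number from compound 2 to compound 3 (0.02 log units; within the scatter) is expected to stay within the scatter, in no particular direction. The number for compound 3 in this assay is therefore estimated at 150000 nM, with a range from 60000 nM to 350000 nM.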

Compound 3, half-maximal inhibitory concentration: 190000 nM
Estimate against measurement, compound 3: 1.3-fold (0.10 log units) below; low and high end bracket the measured number.
By their numbers in this assay, from the lowest: compounds 2, 1 and 3 (each within the scatter of the next).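

In this assay, among these compounds, a bromo group in place of hydrogen on the aromatic carbon ortho to a hydroxy group gives a 1.2-fold higher number from compound 2 to compound 3 (0.09 log units; within the scatter) and so, for the first time, shows that filling this position with a bromine leaves compound 3 indistinguishable from its parent. The whole exchange of 4-fluorophenyl for 3,5-dibromo-2-hydroxyphenyl gives a 1.1-fold higher number from compound 1 to compound 3 (0.05 log units; within the scatter) and likewise stays inside the scatter, so neither the single bromine nor the full ring exchange separates these compounds on this read-out. Nothing is available that could explain this flat result.

All the ring substituents shown here are fluoro, bromo and hydroxy groups, so it remains open whether an amine or a carboxylic acid on the aromatic carbon ortho to the hydroxy group would take the number beyond the scatter. Going by these compounds, it is equally open whether a longer chain there, or a change in the shared core away from this ring, would separate a compound from these three.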